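Removing the fluoro group from an inactive amide

The source may report more compounds than this note shows. Statements on the series, on what has been measured and on what is new or still open speak of the compounds shown alone.

Measured so far in a functional assay on T47D cells (Homo sapiens) for antiproliferative activity, read by MTT assay, with a stated time of 72 h; a lower number here means a stronger inhibitor, a higher number a weaker inhibitor:
compound 1 `O=C(Nc1ccc(Cl)c(-c2nnc3c(Cl)cccn23)c1)c1ccc(F)cc1Cl` gives > 100000 nM, a limit of the assay.
compound 2 `O=C(Nc1ccc(Cl)c(-c2nnc3c(Cl)cccn23)c1)c1cccnc1Cl` gives > 100000 nM, also a limit of the assay.

Within the data shown here, compound 1 stands only at a limit in this assay, and the one other value shown is a limit as well. Among the measured compounds shown here, the only measured step, a step that the two limits leave unreadable from compound 1 to compound 2, changes the acyl side of the amide, and because both ends sit at the limit of > 100000 nM in this assay, at which 2 of the 2 values shown sit, its size cannot be read.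

Compound 3 `O=C(Nc1ccc(Cl)c(-c2nnc3c(Cl)cccn23)c1)c1ccccc1Cl` differs from compound 1 in one place: hydrogen in place of fluoro on an aromatic carbon. The change keeps the 2-chlorophenyl amide and the shared core untouched.

For the measured compounds named here, no measured step bears directly on this change, and the one step that is known gives no size at all. With both measured compounds sitting at the limit, the expectation is that compound 3 will also be reported only as a limit in this assay, so the expected step of a number no higher from compound 1 to compound 3 (the limit leaves the size open) is none that could be read beyond the scatter. The estimate for compound 3 is therefore 100000 nM, between 30000 nM and 300000 nM.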

Compound 3, half-maximal inhibitory concentration: 83800 nM
For compound 3 the middle estimate is 1.2-fold (0.08 log units) above the measured one; the range from low to high includes it.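

In this assay, among these compounds, compound 3 is the first of these amides to give a real number instead of a limit, at 83800 nM. Hydrogen in place of the fluoro group, on the aromatic carbon para to a large group, gives an at least 1.1-fold lower number from compound 1 to compound 3 (0.07 log units; that floor lies within the scatter), and 2-chlorophenyl in place of 2-chloropyridin-3-yl gives an at least 1.1-fold lower number from compound 2 to compound 3 (0.07 log units; that floor lies within the scatter). Each of these steps has a limit at one end, so it gives only a floor and not a size, the true gap may be larger or may be nothing beyond the scatter, and the step between compound 1 and compound 2 still cannot be read: the limit of > 100000 nM in this assay, at which 2 of the 3 values shown sit.

From the compounds shown here alone, it remains open whether a different group on that same aromatic carbon, such as an amine, a methoxy group or a carboxylic acid, would shift the number beyond the scatter. Going by these compounds, it is also open whether replacing the chloro group of the 2-chlorophenyl amide, or changing the shared core, would bring this series into a range where steps can be read in full.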